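The source may report more compounds than this note shows. Statements on the series, on what has been measured and on what is new or still open speak of the compounds shown alone.

Measured compounds:
compound 1, `CCCCCCCCCCCCCCCCCCNC(=O)[C@@H](NC(=O)c1ccco1)[C@@H](C)O`, 13400 nM
compound 2, `CCCCCCCCCCCCCCCCCCNC(=O)[C@@H](NC(=O)/C=C/c1ccccc1)[C@@H](C)O`, 35900 nM

In a functional assay on SiHa cells (Homo sapiens) for cytotoxicity, read by MTT assay, with a stated time of 48 h (on this read-out higher numbers stand for weaker inhibition and lower numbers for stronger inhibition), compound 2 gives the higher of the two numbers, and the step of a 2.7-fold higher number from compound 1 to compound 2 (0.43 log units; beyond the scatter) separates it from compound 1. Compound 3, `C/C=C/C=C/C(=O)N[C@H](C(=O)NCCCCCCCCCCCCCCCCCC)[C@@H](C)O`, differs from compound 2 by prop-1-en-1-yl in place of phenyl on a double-bonded chain carbon bound to a double-bonded chain carbon. Among the compounds with values here, no measured step swaps an aromatic ring for a chain at this carbon, so the only step seen, a 2.7-fold higher number from compound 1 to compound 2 (0.43 log units; beyond the scatter), does not bear directly on this change. Compound 3 is therefore expected to give 30000 nM, between 12000 nM and 80000 nM, a step of a 1.2-fold lower number from compound 2 to compound 3 (0.08 log units; within the scatter) that is not expected to exceed the scatter.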

Compound 3, half-maximal inhibitory concentration: > 200000 nM
Compound 3 was reported as a limit; the forecaster's own chance of this, stated with the estimate: 10%; at least 6.6-fold (0.82 log units) between middle value and limit.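

In this assay, prop-1-en-1-yl in place of phenyl on a double-bonded chain carbon bound to a double-bonded chain carbon gives an at least 5.5-fold higher number from compound 2 to compound 3 (0.74 log units; beyond the scatter), while the wider comparison gives an at least 14-fold higher number from compound 1 to compound 3 (1.17 log units; beyond the scatter); both steps are bounds, not exact sizes. Compound 3 gives only a limit, not a number: the limit of > 200000 nM in this assay, at which 1 of the 3 values shown sits. Among these three compounds, the acyl group matters more than compound 1 and compound 2 suggested, and only compound 3 lacks a ring in it. Going by these compounds, whether a saturated propyl chain or a pyridine ring would keep a measurable number remains open.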